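Aryl ketone swap from compound 3 to compound 4

A few compounds are considered here, and "the series" means these few. Any claim that something is new, unique, unknown or untested is made for them only; others in the source may bear on it.

Compound 3 `COc1ccc(-c2csc(NC(=O)COc3ccc(C(=O)c4ccc(F)cc4)cc3C)n2)cc1` gives the lowest number of the three measured in a functional assay on Ehrlich cells (Mus musculus) for cytotoxicity, read by trypan blue exclusion, with a stated time of 48 h (on this read-out lower numbers stand for stronger inhibition and higher numbers for weaker inhibition), with 5200 nM. Compound 1 `Cc1cc(C(=O)c2ccc(F)cc2)ccc1OCC(=O)Nc1nc(-c2ccccc2)cs1` gives 35200 nM in this assay, and compound 2 `COc1ccc(-c2csc(NC(=O)COc3c(C)cc(C(=O)c4ccccc4)cc3C)n2)cc1` gives 40600 nM in this assay. Going by the values given here, the only single-point step, a 6.8-fold lower number from compound 1 to compound 3 (0.83 log units; beyond the scatter), concerns the methoxy substituent and not the aryl ketone. Compound 4 `COc1ccc(-c2csc(NC(=O)COc3ccc(C(=O)c4cccc(Br)c4)cc3C)n2)cc1` differs from compound 3 by 3-bromophenyl in place of 4-fluorophenyl on a carbonyl carbon. Among the compounds with values here, no measured step touches this part of the series; compound 2 differs from compounds 1 and 3 in more than one place, so its number says nothing about this swap alone. The expectation for compound 4 is therefore a step of a 1.2-fold higher number from compound 3 to compound 4 (0.06 log units; within the scatter), not beyond the scatter. Compound 4 is estimated at 6000 nM in this assay, within 2500 nM to 15000 nM.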

Compound 4, half-maximal inhibitory concentration: 38100 nM
The estimate for compound 4 lay 6.4-fold (0.80 log units) below the measured number; the measured number lies above the stated range.
By their numbers in this assay, from the lowest: compound 3; then compounds 1, 4 and 2 (each within the scatter of the next).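

The aryl group on the ketone carbonyl is not a silent place in this assay: 3-bromophenyl in place of 4-fluorophenyl gives a 7.3-fold higher number from compound 3 to compound 4 (0.86 log units; beyond the scatter). The low number of compound 3 thus rests on its 4-fluorophenyl as well as on the methoxy substituent seen in a 6.8-fold lower number from compound 1 to compound 3 (0.83 log units; beyond the scatter). Nothing measured accounts for this step.

The swap changes both the halogen and its ring place, and these remain unseparated. 4-Bromophenyl and 3-fluorophenyl on the same carbonyl carbon would tell the two apart.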